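The source may report more compounds than this note shows. Statements on the series, on what has been measured and on what is new or still open speak of the compounds shown alone.

Of the compounds shown here, two have so far been measured. Compound 2 `CCCc1c(COc2ccc(C(=O)CC(C)(C)Cc3nnn[nH]3)cc2)ccc(C(C)=O)c1O` gives 7.86 in a functional assay on ileum (Cavia porcellus) with cysteinyl leukotriene receptor (Homo sapiens) as the target; on this read-out higher numbers stand for higher potency (the scale is a negative logarithm) and lower numbers for lower potency. Within the data shown here, its only measured neighbour, compound 1 `CCCc1c(COc2ccc(C(=O)CCCc3nnn[nH]3)cc2)ccc(C(C)=O)c1O`, gives 7.67 in this assay, and the two numbers cannot be told apart. Compound 3 `CCCc1c(COc2ccc(C(=O)CCCCCCc3nnn[nH]3)cc2)ccc(C(C)=O)c1O` is not yet measured; it differs from compound 2 in one place: 5-(1H-tetrazol-5-yl)pentyl in place of 1-((1H-tetrazol-5-yl)methyl)-1-methylethyl on a saturated chain carbon bound to a carbonyl carbon. Among the measured compounds shown here, the one measured step that bears on this is the change in the same chain between the carbonyl and the tetrazole, which read a number 0.19 log units higher from compound 1 to compound 2 (within the scatter), so a reshaping of that chain left the potency unchanged within the scatter. The longer chain of compound 3 reaches beyond anything measured here, so the expectation rests on that single step. Compound 3 is therefore expected to land close to compound 2, with an estimated step of a number 0.26 log units lower from compound 2 to compound 3 (within the scatter) and an estimate of 7.6, plausibly between 6.9 and 8.2.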

Compound 3, negative logarithm of the antagonist equilibrium constant: 7.33
Estimate against measurement, compound 3: 0.27 log units above; the range from low to high includes it.
By their numbers in this assay, from the lowest: compound 3; then compounds 1 and 2 (each within the scatter of the next).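

In this assay, the group on a saturated chain carbon bound to a carbonyl carbon turns out not to be freely interchangeable: 5-(1H-tetrazol-5-yl)pentyl gives a number 0.53 log units lower from compound 2 to compound 3 (beyond the scatter) and also a number 0.34 log units lower from compound 1 to compound 3 (beyond the scatter). Among these compounds, the only earlier step at this place stayed within the scatter, whereas both new steps lie beyond it, although each is modest, and compound 3, with the longest chain, has the lowest number of the three. Nothing measured here speaks to what lies behind this loss of potency.

The compounds shown leave open whether potency falls steadily as the chain grows or only past a certain length, which a butyl chain ending in the tetrazole would help to settle. Also open, on these data alone, is whether the tetrazole itself matters, which a carboxylic acid at the chain end would test.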